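Swapping the Carbamate Aryl Group on a Longer Chain

The compounds below may be only part of what the source reports. "The series", "measured", "known", "first", "only" and "open" are said of these compounds alone.

Compound 1 `CC(C)=CCC1Cc2c(OC(=O)Nc3ccc(F)c(Cl)c3)cc(=O)n(CCCO)c2CC1(C)C` and compound 2 `CC(C)=CCC1Cc2c(OC(=O)Nc3ccc(Cl)cc3)cc(=O)n(CCCO)c2CC1(C)C` share one core and differ only at the carbamate nitrogen, (4-chlorophenyl in place of 3-chloro-4-fluorophenyl on an amide-type nitrogen). In a functional assay on PANC-1 cells (Homo sapiens) for inhibition, read by MTT assay, with a stated time of 24 h, tested at 10 uM (on this read-out lower numbers stand for less inhibition and higher numbers for more inhibition at the one concentration tested (going by the name of the read-out)), compound 1 gives 79.8%, and compound 2 gives 49.8%, so this change gave a number 30 percentage points lower from compound 1 to compound 2 (beyond the scatter). Compound 3 `CC(C)=CCC/C(C)=C/CC1Cc2c(OC(=O)Nc3ccc(F)c(Cl)c3)cc(=O)n(CCCO)c2CC1(C)C` carries a different core, (3-methylbut-2-en-1-yl in place of hydrogen on a saturated chain carbon bound to a double-bonded chain carbon); in this assay compound 3 gives 25%, which is a number 54.8 percentage points lower from compound 1 to compound 3 (beyond the scatter). Compound 4 `CC(C)=CCC/C(C)=C/CC1Cc2c(OC(=O)Nc3ccc(Cl)cc3)cc(=O)n(CCCO)c2CC1(C)C` is not yet measured and differs from compound 3 by 4-chlorophenyl in place of 3-chloro-4-fluorophenyl on an amide-type nitrogen, the same change as from compound 1 to compound 2, made at the same place. Because that change earlier gave a number 30 percentage points lower from compound 1 to compound 2 (beyond the scatter), a further loss of inhibition is expected, though the read-out is already low and cannot fall far. On this basis the step expected for compound 4 is a number 15 percentage points lower from compound 3 to compound 4 (beyond the scatter). The estimate for compound 4 in this assay is 10%, between 0% and 30%.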

Compound 4, a percentage reported as inhibition, at one concentration (the size of the read-out at that concentration, not a potency): 47.2%
Compound 4: the middle estimate sits 37.2 percentage points below what was measured; measured number outside the range, above it.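

In this assay, putting 4-chlorophenyl in place of 3-chloro-4-fluorophenyl on the core of compound 3 gives a number 22.2 percentage points higher from compound 3 to compound 4 (beyond the scatter), so the change does not carry over from the core of compound 1, even in direction: the same change on two cores in this assay, a number 30 percentage points lower (beyond the scatter) from compound 1 to compound 2 and a number 22.2 percentage points higher (beyond the scatter) from compound 3 to compound 4, 52.2 percentage points apart, beyond the scatter of two such steps. Adding 3-methylbut-2-en-1-yl with 4-chlorophenyl in place gives a number 2.6 percentage points lower from compound 2 to compound 4 (within the scatter), which does not match the step seen with 3-chloro-4-fluorophenyl: the same change on two cores in this assay, a number 54.8 percentage points lower (beyond the scatter) from compound 1 to compound 3 and a number 2.6 percentage points lower (within the scatter) from compound 2 to compound 4, 52.2 percentage points apart, beyond the scatter of two such steps. In these four compounds, the outcome of each change depends on the other, but one pair per change establishes no general rule and gives no reason for the reversal.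

It remains open whether 3-chlorophenyl or 4-fluorophenyl on that nitrogen would behave like either group shown. Also open, as far as these compounds go, is how an amine or a carboxylic acid in place of the chain's hydroxyl would behave on these two cores.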